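The source may report more compounds than this note shows. Statements on the series, on what has been measured and on what is new or still open speak of the compounds shown alone.

Notes on the series. Compound 1 `COc1cc(OC)c(OC)cc1/C=C/COC(=O)/C=C/c1c(OC)ccc(OC)c1OC` and compound 2 `COc1cc(OC)c(OC)cc1/C=C/COC(=O)/C=C/c1ccc(Cl)cc1` share the same core and differ in the aryl group attached to the ester-side alkene. In a functional assay on the whole organism (strain Kunming) with Mus musculus as the target, with a stated time of 0.5 h, at a dose of 300 mg/kg by the intraperitoneal route (a lower number here means a stronger effect, a higher number a weaker effect of the compound at the dose given), compound 1 gives 75%, while compound 2 gives 50%. Compound 2 thus stands as the lower of the two numbers, with compound 1 sitting higher by a gap beyond the usual scatter, so compound 2 shows the stronger effect at this dose.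

Compound 3 `COc1ccc(/C=C/C(=O)OC/C=C/c2cc(OC)c(OC)cc2OC)cc1` follows from compound 2 by one change: methoxy in place of chloro on an aromatic carbon. For the measured compounds named here, no step between measured compounds matches this exchange, so its size is open. The expectation is a small move upward, from compound 2 to compound 3, of a number 10 percentage points higher from compound 2 to compound 3 (within the scatter), likely not clearly beyond the scatter. Compound 3 is therefore estimated to give 60% in this assay, within a range of 40% to 85%.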

Compound 3, a percentage reported as activity, at one dose (the size of the read-out at that dose, not a potency): 100%
Compound 3: middle estimate off by 40 percentage points, on the low side, and the stated range ends below it.
By their numbers in this assay, from the lowest: compound 2; then compound 1; then compound 3.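

In this assay, going from 4-chlorophenyl to 4-methoxyphenyl gives a number 50 percentage points higher from compound 2 to compound 3 (beyond the scatter), so the effect at this dose is sensitive to this single group on the aromatic carbon para to a large group. For the compounds shown here, this is the first comparison that isolates one place, and at that place the stronger effect goes with chloro rather than methoxy, which the earlier pair, differing across the whole aryl group, could not show. Nothing available on these compounds bears on the reason for a step of this size.

The compounds shown leave open how a fluoro, bromo or methyl group, or an amine or a carboxylic acid, would read at this place. Also open, as far as these compounds go, is whether the step reflects chloro leaving or methoxy entering.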